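Halogenated phenyl variation on the shared core: compound 4

The source may hold more compounds than are shown below. What is called first, only, known or untested is meant among the compounds shown, and "the series" means these compounds.

Measured compounds:
compound 1 `CCc1ccc(-n2nc(-c3ccc(C(F)(F)F)cc3O)nc2-c2ccccc2O)cc1`: 107%
compound 2 `Oc1cc(C(F)(F)F)ccc1-c1nc(-c2ccccc2O)n(-c2ccc(Br)cc2)n1`: 100%
compound 3 `N#Cc1ccc(-n2nc(-c3ccc(C(F)(F)F)cc3O)nc2-c2ccccc2O)cc1`: 98.9%

In a functional assay on PC-12 cells (Rattus norvegicus) for cytotoxicity, read by MTT assay, with stated times of 2 h and 24 h, tested at 10 uM (on this read-out higher numbers stand for a stronger effect at the one concentration tested and lower numbers for a weaker effect), compound 2 stands second highest of the three. Its nearest neighbour is compound 3, a number 1.1 percentage points lower from compound 2 to compound 3 (within the scatter); the furthest is compound 1, a number 7 percentage points lower from compound 1 to compound 2 (within the scatter). Compound 4 `Oc1cc(C(F)(F)F)ccc1-c1nc(-c2ccccc2O)n(-c2cccc(Cl)c2)n1` is not yet measured. The change is 3-chlorophenyl in place of 4-bromophenyl on an aromatic nitrogen. Every measured step alters the group on this same aryl ring: a number 7 percentage points lower from compound 1 to compound 2 (within the scatter), a number 8.1 percentage points lower from compound 1 to compound 3 (within the scatter) and a number 1.1 percentage points lower from compound 2 to compound 3 (within the scatter), none beyond the scatter. A further halogen swap on that aryl is therefore expected to give no step beyond the scatter, the expected step being no change at the digits printed from compound 2 to compound 4 (within the scatter). Compound 4 is estimated at 100% in this assay, within 88% to 112%.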

Compound 4, a percentage reported as activity, at one concentration (the size of the read-out at that concentration, not a potency): 100%
Beside the measured number, compound 4's estimate shows no gap at the digits printed, within the range that was stated.
By their numbers in this assay, from the lowest: compounds 3, 2, 4 and 1 (each within the scatter of the next).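

For the compounds shown here, compound 4 is the first here to carry 3-chlorophenyl on the aromatic nitrogen, in place of a 4-bromophenyl, 4-cyanophenyl or 4-ethylphenyl group, and in this assay the step is no change at the digits printed from compound 2 to compound 4 (within the scatter). The other two steps, a number 1.1 percentage points higher from compound 3 to compound 4 (within the scatter) and a number 7 percentage points lower from compound 1 to compound 4 (within the scatter), show that neither the group nor its place on this aryl ring is separated by this read-out across the four compounds. No supporting measurement bears on this result.

Open, from the compounds shown here alone, is whether an aryl ring bearing an amine or a carboxylic acid at this nitrogen would give a step beyond the scatter.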